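Methoxy Added to a Hydroxy Analogue of a Quaternary Indole

This account rests on a few compounds, and the source may have more. Where it says the series, first, only, none or still open, it means among the compounds named here.

Compound 1 `C[N+](C)(C)Cc1cn(Cc2ccccc2)c2ccccc12` gives 4200 nM in an assay on HEK293 cells for antagonist activity at Neuronal acetylcholine receptor; alpha4/beta2 (Homo sapiens), read by calcium flux; on this read-out lower numbers stand for stronger inhibition and higher numbers for weaker inhibition. Compound 2 `C[N+](C)(C)Cc1cn(Cc2ccc(O)cc2)c2ccccc12` carries hydroxy in place of hydrogen on an aromatic carbon, and in this assay compound 2 gives 24900 nM, a step of a 5.9-fold higher number from compound 1 to compound 2 (0.77 log units; beyond the scatter). Compound 3 `COc1ccc(Cn2cc(C[N+](C)(C)C)c3ccccc32)cc1` carries methoxy in place of hydrogen on an aromatic carbon, and in this assay compound 3 gives 4400 nM, so the step is a 1.0-fold higher number from compound 1 to compound 3 (0.02 log units; within the scatter). The unmeasured compound 4 `COc1cc(Cn2cc(C[N+](C)(C)C)c3ccccc32)ccc1O` is built from compound 2 by methoxy in place of hydrogen on an aromatic carbon. This is the same kind of change as from compound 1 to compound 3, not the same one: in compound 3 the methoxy sits para to a large group, in compound 4 ortho to a hydroxy group and meta to a large group. Because a 1.0-fold higher number from compound 1 to compound 3 (0.02 log units; within the scatter) lies within the scatter, the step expected from compound 2 to compound 4 is a 1.2-fold lower number from compound 2 to compound 4 (0.10 log units; within the scatter). Compound 4 is therefore estimated at 20000 nM, expected to fall between 7000 nM and 60000 nM.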

Compound 4, half-maximal inhibitory concentration: 9100 nM
The estimate for compound 4 lay 2.2-fold (0.34 log units) above the measured number, and the stated range covers the measured number.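

On the core of compound 2, the added methoxy in this assay gave a 2.7-fold lower number from compound 2 to compound 4 (0.44 log units; beyond the scatter). Set beside the earlier case, the same kind of change did not carry over with the same size from one core to the other: the same change on two cores in this assay, a 1.0-fold higher number (0.02 log units; within the scatter) from compound 1 to compound 3 and a 2.7-fold lower number (0.44 log units; beyond the scatter) from compound 2 to compound 4, 2.9-fold (0.46 log units) apart, beyond the scatter of two such steps. This shows that the step seen on compound 1 cannot simply be transferred within this series, but it does not show that the core alone sets the size of the step, since the methoxy in compound 4 also sits ortho to a hydroxy group and meta to a large group.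

Going by these compounds, it remains open whether methoxy at that same place gives this step on a core without the hydroxy group. On these data alone, whether an ethoxy group, a fluorine or an amine there would move the number as methoxy does also stays open.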